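Methylation of a Phenol on a Flavonol-Terpene Hybrid

A few compounds are considered here, and "the series" means these few. Any claim that something is new, unique, unknown or untested is made for them only; others in the source may bear on it.

The series is built around compound 1 `C=C1CC[C@H]2C(C)(C)CCC[C@]2(C)[C@H]1CC/C(C)=C/Cc1c(O)cc(O)c2c(=O)c(O)c(-c3ccc(O)cc3)oc12` and compound 2 `C=C1CC[C@H]2C(C)(C)CCC[C@]2(C)[C@H]1CC/C(C)=C/COc1c(-c2ccc(O)cc2)oc2cc(O)cc(O)c2c1=O`, which have the same atoms joined differently; the difference between the two cores is not broken down here. In a functional assay on HeLa cells (Homo sapiens) for cytotoxicity, read by XTT assay, with a stated time of 72 h (on this read-out lower numbers stand for stronger inhibition and higher numbers for weaker inhibition), compound 1 gives 30000 nM. In this assay compound 2 gives 27000 nM, a value within the scatter of that of compound 1, so no order between the two can be read. Compound 3 `C=C1CC[C@H]2C(C)(C)CCC[C@]2(C)[C@H]1CC/C(C)=C/Cc1c(O)cc(O)c2c(=O)c(O)c(-c3ccc(OC)cc3)oc12` carries the change methyl in place of hydrogen on an oxygen on an aromatic ring relative to compound 1. In this assay compound 3 reaches only a limit, > 100000 nM. The step of an at least 3.3-fold higher number from compound 1 to compound 3 (0.52 log units; beyond the scatter) therefore runs into (the limit of > 100000 nM in this assay, at which 1 of the 3 values shown sits), and its true size is not known beyond being at least modest.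

Compound 4 `C=C1CC[C@H]2C(C)(C)CCC[C@]2(C)[C@H]1CC/C(C)=C/COc1c(-c2ccc(OC)cc2)oc2cc(O)cc(O)c2c1=O` stands to compound 2 as compound 3 stands to compound 1: the change methyl in place of hydrogen on an oxygen on an aromatic ring is the same, at the same place, on an oxygen on an aromatic ring whose other neighbour is an aromatic carbon. Since compound 2 gives 27000 nM, a value within the scatter of that of compound 1, the same change is expected to weaken compound 4 to a similar degree. The step expected is a 3.7-fold higher number from compound 2 to compound 4 (0.57 log units; beyond the scatter), beside the measured at least 3.3-fold higher number from compound 1 to compound 3 (0.52 log units; beyond the scatter). For compound 4 in this assay the estimate is 100000 nM, with a range from 45000 nM to 300000 nM, and a sizeable chance that again only a limit is reported.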

Compound 4, half-maximal inhibitory concentration: 30000 nM
For compound 4 the middle estimate is 3.3-fold (0.52 log units) above the measured one, and the stated range ends above it.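

In this assay, methyl in place of hydrogen on an oxygen on an aromatic ring gives a 1.1-fold higher number from compound 2 to compound 4 (0.05 log units; within the scatter), so on this core the change from 4-hydroxyphenyl to 4-methoxyphenyl leaves no readable difference. The weakening seen on the core of compound 1 therefore did not carry over to the other core, and the two results differ: the same change on two cores in this assay, an at least 3.3-fold higher number (0.52 log units; beyond the scatter) from compound 1 to compound 3 and a 1.1-fold higher number (0.05 log units; within the scatter) from compound 2 to compound 4, at least 3.0-fold (0.47 log units) apart, beyond the scatter of two such steps This shows that, for this one pair of cores, the effect of the change cannot be assumed to transfer, but it gives no general rule for the series and no reason for the difference, and the gap has only a lower bound since one of the two steps ends at a limit: the limit of > 100000 nM in this assay, at which 1 of the 4 values shown sits.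

The compounds shown leave open whether other groups on the same oxygen, such as ethyl, a longer chain or a chain ending in an amine or a carboxylic acid, would also separate the two cores. They also leave open whether the same methyl on one of the other hydroxy groups would behave alike on both cores, or whether the split seen here belongs to this one place alone.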